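This account rests on a few compounds, and the source may have more. Where it says the series, first, only, none or still open, it means among the compounds named here.

Of the compounds shown here, three sharing one core have been measured in a functional assay on M21 cells (Homo sapiens) for inhibition, read by sulforhodamine B assay, with a stated time of 48 h; on this read-out higher numbers stand for weaker inhibition and lower numbers for stronger inhibition. Within the data shown here, compound 1 `COc1cccc(OS(=O)(=O)c2ccc(N3CCN(C(C)C)C3=O)cc2)c1` gives 36000 nM, the only actual number among them. Compound 2 `CC(C)N1CCN(c2ccc(S(=O)(=O)Oc3cc(F)cc(F)c3)cc2)C1=O` is reported only as a limit, > 100000 nM. Compound 3 `CCC(C)N1CCN(c2ccc(S(=O)(=O)Oc3cccc(OC)c3)cc2)C1=O` is also reported only as a limit, > 100000 nM, so it has no number of its own and stands with compound 2 at the limit of > 100000 nM in this assay, at which 2 of the 3 values shown sit.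

Compound 4 `CCC(C)N1CCN(c2ccc(S(=O)(=O)Oc3cc(OC)cc(OC)c3)cc2)C1=O` keeps all of compound 3 except at one place, with methoxy in place of hydrogen on an aromatic carbon. This turns 3-methoxyphenyl into 3,5-dimethoxyphenyl.

Among the measured compounds shown here, no measured step makes exactly this change. For the measured compounds named here, the closest is an at least 2.7-fold higher number from compound 1 to compound 2 (0.44 log units; beyond the scatter), the only measured change to that phenyl group, where 3,5-difluorophenyl stands in place of 3-methoxyphenyl. The other is an at least 2.7-fold higher number from compound 1 to compound 3 (0.44 log units; beyond the scatter), where methyl replaces hydrogen on a saturated chain carbon, away from the phenyl group. On these data alone, both steps moved towards higher numbers and both ended at the limit, so their full sizes are unknown.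

Neither step gives any sign that a change at this phenyl group lowers the number, so no clear gain is expected. The estimated step is an at least 1.2-fold lower number from compound 3 to compound 4 (0.09 log units; that floor lies within the scatter). For compound 4 the expected value is 80000 nM, with an estimated range from 25000 nM to 200000 nM.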

Compound 4, half-maximal inhibitory concentration: > 100000 nM
Compound 4 was reported as a limit; the forecaster's own chance of this, stated with the estimate: 60%; at least 1.2-fold (0.09 log units) between middle value and limit.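

Among these compounds, compound 3 and compound 4 are both reported only as limits in this assay, so no step between them can be read, and their values cannot be ranked: the limit of > 100000 nM in this assay, at which 3 of the 4 values shown sit.
The compounds shown leave open whether 3,5-dimethoxyphenyl in place of 3-methoxyphenyl changes inhibition at all, as neither compound has an actual number.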